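Cytotoxicity of three quinoline-type amines and a biaryl analogue

The compounds below may be only part of what the source reports. "The series", "measured", "known", "first", "only" and "open" are said of these compounds alone.

Three compounds sharing one core were tested in an ADME assay on HepG2 cells (Homo sapiens) for cytotoxicity, read by luminescence, CellTiter-Glo and ATP content, with a stated time of 72 h; on this read-out lower numbers stand for an effect already at smaller amounts and higher numbers for an effect only at larger amounts of compound. Compound 1 `COc1cccc(Oc2ccc3c(NCCCNCc4cc(F)ccc4OC)ccnc3c2)c1` gives 7100 nM. Compound 2 `COc1cccc(CNCCCNc2ccnc3cc(Cc4ccccc4)ccc23)c1O` gives 5720 nM, and compound 3 `COc1cccc(Oc2ccc3c(NCCCNCc4cccc(OC)c4O)ccnc3c2)c1` gives 5300 nM. Compound 1 holds the highest of the three numbers, but its nearest neighbour compound 2 and its furthest neighbour compound 3 both sit within the usual scatter of it, so the three values are best read as one cluster rather than as an order.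

Two single-point changes connect them. The step of a 1.3-fold lower number from compound 1 to compound 3 (0.13 log units; within the scatter) changes the group on the saturated chain carbon bound to an amine nitrogen; the step of a 1.1-fold lower number from compound 2 to compound 3 (0.03 log units; within the scatter) changes the group on the aromatic carbon of the core. Neither moves the number beyond the scatter.

Compound 4 `COc1ccc(-c2ccc3c(NCCCNCc4cc(F)ccc4OC)ccnc3c2)cc1` differs from compound 1 at that same aromatic carbon: 4-methoxyphenyl in place of 3-methoxyphenoxy on an aromatic carbon. For the measured compounds named here, the one step that bears on this position, from compound 2 to compound 3, left the number essentially unchanged, so no shift beyond the scatter is expected here either. Compound 4 is therefore estimated at 6500 nM, within a range of 3200 nM to 13000 nM, which means an expected step of a 1.1-fold lower number from compound 1 to compound 4 (0.04 log units; within the scatter).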

Compound 4, half-maximal effective concentration: 5960 nM
For compound 4 the middle estimate is 1.1-fold (0.04 log units) above the measured one, within the range that was stated.
By their numbers in this assay, from the lowest: compounds 3, 2, 4 and 1 (each within the scatter of the next).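

Compound 4 puts 4-methoxyphenyl in place of 3-methoxyphenoxy on the aromatic carbon of the shared core, and in this assay this gives a 1.2-fold lower number from compound 1 to compound 4 (0.08 log units; within the scatter). The earlier step at this position was read with a 2-hydroxy-3-methoxyphenyl group on the chain, whereas this one is read with a 5-fluoro-2-methoxyphenyl group there, so the finding of no difference beyond the scatter now holds for two different chain groups and for a third group at this carbon. The change also takes away one oxygen atom and one hydrogen-bond acceptor by count, yet the result stays within the scatter, and no measurement is available that could explain this result.

All three groups seen at this aromatic carbon carry a six-membered aromatic ring of carbon only, so it remains open whether an amine such as morpholine or a carboxylic acid at the same place would stay within the scatter of these compounds. Going by these compounds, it also remains open whether a longer chain on the shared core would leave the number in this assay within that same cluster.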